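Dimethylamino for fluoro on the pendant aromatic ring

The source may report more compounds than this note shows. Statements on the series, on what has been measured and on what is new or still open speak of the compounds shown alone.

Of the compounds shown here, three have been measured in an assay on isolated protein for inhibition of Aromatase (Homo sapiens), read by fluorescence, using NADPH, with a stated time of 30 min, tested at 50 uM; on this read-out higher numbers stand for more inhibition at the one concentration tested (going by the name of the read-out) and lower numbers for less inhibition. Compound 1 `Fc1ccc(-c2cc3ccccc3[nH]2)cc1` gives 21.8%. Compound 2 `O=[N+]([O-])c1ccc2[nH]c(-c3cccnc3)cc2c1` gives 27.9%, and compound 3 `Clc1ccccc1-c1cc2ccccc2[nH]1` gives 21.5%. Compound 1 stands second highest of the three numbers, but its gaps to compound 3 and to compound 2 both lie within the scatter, so the three cannot be ordered.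

Compound 4 `CN(C)c1ccc(-c2cc3ccccc3[nH]2)cc1` differs from compound 1 in one place: dimethylamino in place of fluoro on an aromatic carbon. For the measured compounds named here, no step between measured compounds covers this change, so nothing sets its size. The expectation is a step in this assay of no more than modest size, if any, probably not beyond the scatter. The step of a number 3.2 percentage points higher from compound 1 to compound 4 (within the scatter) is the estimate. Compound 4 is expected to give 25%, with a range from 8% to 45%.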

Compound 4, a percentage reported as inhibition, at one concentration (the size of the read-out at that concentration, not a potency): 0%
Estimate against measurement, compound 4: 25 percentage points above; the measured number lies below the stated range.
By their numbers in this assay, from the lowest: compound 4; then compounds 3, 1 and 2 (each within the scatter of the next).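

Dimethylamino in place of fluoro on this aromatic carbon, para to a group of 9 heavy atoms, gives in this assay a number 21.8 percentage points lower from compound 1 to compound 4 (beyond the scatter). For the compounds shown here, this is the first step, and it shows that one change at this place can take the read-out to 0% in compound 4. Nothing at hand accounts for this drop.

As far as these compounds go, it remains open whether the drop belongs to the dimethylamino group as a whole or to its nitrogen. A primary amine or a methoxy group on this same carbon would bear on that question.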